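Compound 2: methoxy out, (oxetan-3-yl)amino in

The compounds below may be only part of what the source reports. "The series", "measured", "known", "first", "only" and "open" are said of these compounds alone.

Of the compounds shown here, three have been read so far. In a functional assay (strain AB) with Danio rerio as the target, read by microscopy, with a stated time of 1 h (a higher number here means that more compound is needed for the effect, a lower number that less compound is needed), compound 1 `CCN1CCc2c(sc(NC(=O)C3(c4ccc(Cl)cc4)CC3)c2C(N)=O)C1` gives > 25000 nM, which is a limit and not a number. Compound 2 `CCN1CCc2c(sc(NC(=O)Nc3ccc(Cl)cc3)c2C(=O)OC)C1` gives > 25000 nM, which is also a limit and not a number. Going by the values given here, compound 3 `CC1(C)Cc2c(sc(NC(=O)Nc3ccc(Cl)cc3)c2C(N)=O)C(C)(C)N1` gives 1240 nM, the only actual number in the set. Compound 2 thus sits on (the limit of > 25000 nM in this assay, at which 2 of the 3 values shown sit).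

Compound 4 `CCN1CCc2c(sc(NC(=O)Nc3ccc(Cl)cc3)c2C(=O)NC2COC2)C1` differs from compound 2 in one place: (oxetan-3-yl)amino in place of methoxy on a carbonyl carbon. This puts (oxetan-3-yl)amino in place of methoxy on a carbonyl carbon, so methoxycarbonyl becomes (oxetan-3-yl)carbamoyl.

Among the compounds with values here, no step between measured compounds is available to size this change. Compound 3 carries an amide rather than an ester on that carbonyl carbon, although it also differs elsewhere. Compound 1 also carries an amide there, and its result is a limit, > 25000 nM. On the reading of compound 3 at 1240 nM, a move toward less compound needed in this assay is expected. Even so, compound 4 may well stay at the limit. The expected step is an at least 3.1-fold lower number from compound 2 to compound 4 (0.49 log units; beyond the scatter). For compound 4 the estimated value is 8000 nM, with an expected range of 1500 nM to 25000 nM.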

Compound 4, half-maximal effective concentration: > 25000 nM
Compound 4 ended at the assay's limit; the forecaster's own chance of this, stated with the estimate: 45%; middle value at least 3.1-fold (0.49 log units) away from the limit.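

In this assay compound 2 gives > 25000 nM, a limit and not a number. Going by these compounds alone, compound 4 gives > 25000 nM, also a limit, and no step from compound 2 to compound 4 can be read. The compounds shown leave open whether (oxetan-3-yl)amino in place of methoxy on a carbonyl carbon changes the read-out at all.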